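The compounds below may be only part of what the source reports. "The series", "measured", "known", "first", "only" and "open" are said of these compounds alone.

Of the compounds shown here, three sharing one core have been tested in an assay on isolated protein for binding affinity to 5-hydroxytryptamine receptor 6 (Homo sapiens); on this read-out lower numbers stand for stronger inhibition and higher numbers for weaker inhibition. Compound 1 `Cc1cccc(-c2n[nH]cc2N2CCCNCC2)c1` carries a methyl group, and in this assay compound 1 gives 636 nM. Compound 2 `Fc1ccc(-c2n[nH]cc2N2CCCNCC2)cc1` carries a fluorine, and in this assay compound 2 gives 2290 nM. Compound 3 `COc1ccccc1-c1n[nH]cc1N1CCCNCC1` carries a methoxy group instead. For compound 3 the assay reports only a limit, > 10000 nM, and not a number. Compound 3 therefore stands at the limit of > 10000 nM in this assay, at which 1 of the 3 values shown sits, the weak end of what was measured, without an exact value.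

Compound 4 `c1ccc(-c2n[nH]cc2N2CCCNCC2)cc1` differs from compound 3 in one place: hydrogen in place of methoxy on an aromatic carbon. Among the measured compounds shown here, no measured pair of compounds shows this same change, so the step can only be estimated. Because compound 3 sits at the limit of > 10000 nM in this assay, at which 1 of the 3 values shown sits, the expected direction is toward stronger binding, estimated as a step of an at least 6.6-fold lower number from compound 3 to compound 4 (0.82 log units; beyond the scatter). Compound 4 is accordingly expected to reach about 1500 nM in this assay, with a likely range from 400 nM to 6000 nM.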

Compound 4, inhibition constant: 3480 nM
Beside the measured number, compound 4's estimate is 2.3-fold (0.37 log units) below it, and the stated range covers the measured number.
By their numbers in this assay, from the lowest: compound 1; then compounds 2 and 4 (each within the scatter of the next). At a limit, above all of these: compound 3.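

Compound 4, with only hydrogen on its six-membered aromatic ring, gives the other compounds a baseline, and against it a methoxy group ortho to a large group proves unfavourable in this assay: hydrogen in its place gives an at least 2.8-fold lower number from compound 3 to compound 4 (0.45 log units; beyond the scatter), a step that starts from a limit: the limit of > 10000 nM in this assay, at which 1 of the 4 values shown sits. Fluoro and hydrogen cannot be told apart, with a 1.5-fold higher number from compound 2 to compound 4 (0.18 log units; within the scatter). Methyl is the only group shown that improves on hydrogen, since hydrogen in its place gives a 5.5-fold higher number from compound 1 to compound 4 (0.74 log units; beyond the scatter).

Among the compounds shown here, each group appears at only one place on the ring, so how methyl, fluoro or methoxy would fare at another place remains open. Also open, from the compounds shown here alone, is whether an ethyl group would keep the advantage seen with methyl, and how a chlorine, a hydroxyl group or an amine would compare.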